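The source may hold more compounds than are shown below. What is called first, only, known or untested is meant among the compounds shown, and "the series" means these compounds.

Of the compounds shown here, three built on one shared core have been measured in a functional assay on A549 cells (Homo sapiens) for cytotoxicity, read by MTT assay, with a stated time of 24 h; on this read-out higher numbers stand for weaker inhibition and lower numbers for stronger inhibition. Compound 1 `COc1ccc(/C=C(\C#N)C(=O)N/N=C(\C)c2c(O)c3ccc(O)cc3oc2=O)cc1` gives 8150 nM. Compound 2 `C/C(=N\NC(=O)/C(C#N)=C/c1ccc(Br)cc1)c1c(O)c2ccc(O)cc2oc1=O` gives 11400 nM. Compound 3 `C/C(=N\NC(=O)/C(C#N)=C/c1cccc([N+](=O)[O-])c1)c1c(O)c2ccc(O)cc2oc1=O` gives 21900 nM, the highest number of the three; its gap to compound 2 lies within the scatter, while its gap to compound 1 lies beyond it. The measured steps are as follows: a 2.7-fold higher number from compound 1 to compound 3 (0.43 log units; beyond the scatter); a 1.9-fold higher number from compound 2 to compound 3 (0.28 log units; within the scatter); a 1.4-fold higher number from compound 1 to compound 2 (0.15 log units; within the scatter).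

Compound 4 `C/C(=N\NC(=O)/C(C#N)=C/c1ccccc1[N+](=O)[O-])c1c(O)c2ccc(O)cc2oc1=O` has not yet been measured. 2-nitrophenyl in place of 3-nitrophenyl on a double-bonded chain carbon bound to a double-bonded chain carbon The group that leaves and the group that enters are counted as the same atoms joined differently. Among the measured compounds shown here, none of the measured steps is of this kind: each swaps one aryl group for a different one, and even those swaps gave steps that were within or only modestly beyond the scatter. A change that keeps the same atoms is therefore expected to give a step in this assay no larger than those, with no clear direction. Compound 4 is expected to give 20000 nM, with a range from 8000 nM to 50000 nM. This estimate means a step of a 1.1-fold lower number from compound 3 to compound 4 (0.04 log units; within the scatter), which is expected to remain within the scatter.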

Compound 4, half-maximal inhibitory concentration: 11400 nM
Estimate against measurement, compound 4: 1.8-fold (0.24 log units) above; the range from low to high includes it.
By their numbers in this assay, from the lowest: compounds 1, 2, 4 and 3 (each within the scatter of the next, the first and the last beyond it).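

In this assay, among the compounds shown here, 2-nitrophenyl in place of 3-nitrophenyl is the only step so far that keeps the same atoms, and it gives a 1.9-fold lower number from compound 3 to compound 4 (0.28 log units; within the scatter), so this rearrangement at this position cannot be told apart from the scatter of repeated measurements. The other two new steps, no change at the digits printed from compound 2 to compound 4 (within the scatter) and a 1.4-fold higher number from compound 1 to compound 4 (0.15 log units; within the scatter), also lie within the scatter, whereas the earlier 2.7-fold higher number from compound 1 to compound 3 (0.43 log units; beyond the scatter) lies beyond it, which shows that carrying a nitro group does not by itself set a compound clearly apart from compound 1 here. Nothing available explains why the 3-nitrophenyl and 2-nitrophenyl compounds stand as they do against compound 1.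

As far as these compounds go, all four compounds carry a substituted phenyl ring at this place, so it remains open how 4-nitrophenyl, an aminophenyl, a carboxyphenyl or a plain alkyl chain would read out in this assay. From the compounds shown here alone, with every value coming from a single cell line and a single exposure time, it also remains open whether these small gaps would look the same under other conditions.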